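Adding a Third Methoxy Group: Notes Toward Compound 4

A few compounds are considered here, and "the series" means these few. Any claim that something is new, unique, unknown or untested is made for them only; others in the source may bear on it.

Measured so far in a functional assay on PC-3 cells (Homo sapiens) for cytotoxicity, read by sulforhodamine B assay, with a stated time of 48 h; on this read-out lower numbers stand for stronger inhibition and higher numbers for weaker inhibition:
- compound 1, `COc1ccc(C2CC(c3ccco3)=NN2C(C)=O)cc1`: compound 1 gives 15500 nM
- compound 2, `COc1ccc(OC)c(C2CC(c3ccco3)=NN2C(C)=O)c1`: compound 2 gives 11200 nM
- compound 3, `COc1ccc(C2CC(c3ccco3)=NN2C(C)=O)cc1OC`: compound 3 gives 12300 nM

The three numbers sit close together. Compound 3 stands between the other two, with compound 2 nearest and compound 1 furthest, and the gap to each lies within the scatter of this assay. For the measured compounds named here, the only one-place step among them runs from compound 1 to compound 3: a 1.3-fold lower number from compound 1 to compound 3 (0.10 log units; within the scatter).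

Compound 4, `COc1cc(OC)c(C2CC(c3ccco3)=NN2C(C)=O)cc1OC`, is not yet measured. Relative to compound 3 the change is methoxy in place of hydrogen on an aromatic carbon.

Going by the values given here, the step that bears on this change is the one from compound 1 to compound 3, which is the same kind of change, methoxy for hydrogen on the aromatic ring, and it stayed within the scatter. Among the compounds with values here, nothing else speaks to a third methoxy group, so no separate precedent exists for it. The expectation is therefore a step of a 1.0-fold lower number from compound 3 to compound 4 (0.01 log units; within the scatter), that is, nothing beyond the scatter in either direction.

The estimate for compound 4 in this assay is 12000 nM, with a range from 6000 nM to 24000 nM.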

Compound 4, half-maximal inhibitory concentration: 8980 nM
Compound 4: the middle estimate sits 1.3-fold (0.13 log units) above what was measured, within the range that was stated.
By their numbers in this assay, from the lowest: compounds 4, 2, 3 and 1 (each within the scatter of the next).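

In this assay, for the compounds shown here, a methoxy on the aromatic carbon that is ortho to a large group, meta to a methoxy group and para to a methoxy group gives a 1.4-fold lower number from compound 3 to compound 4 (0.14 log units; within the scatter), the first reading of a third methoxy group on this ring and of this position. Reached from the other dimethoxy compound, the third methoxy group gives a 1.2-fold lower number from compound 2 to compound 4 (0.10 log units; within the scatter), so both steps into compound 4 stay within the scatter and neither shows this position to be sensitive to methoxy in place of hydrogen. The change also reads alike in two settings, which the single earlier step could not show: the same change on two cores in this assay, a 1.3-fold lower number (0.10 log units; within the scatter) from compound 1 to compound 3 and a 1.2-fold lower number (0.10 log units; within the scatter) from compound 2 to compound 4, 1.0-fold (0.00 log units) apart, within the scatter of two such steps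

All the ring substituents shown are methoxy groups, which leaves open whether an amine, a carboxylic acid or a longer chain such as butoxy at this position would give a step beyond the scatter. The acetyl group and the rest of the shared core are the same throughout, so these compounds also leave open whether methoxy in place of hydrogen would read the same with another group there, such as a propionyl group.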